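Methoxy in Place of Dimethylamino: An Expectation for Compound 4

The source may report more compounds than this note shows. Statements on the series, on what has been measured and on what is new or still open speak of the compounds shown alone.

Compound 1 `Cc1nc2ccccc2c(=O)n1NCc1nnc(/N=C/c2ccc(N(C)C)cc2)s1` and compound 2 `COc1ccc(/C=N/c2nnc(CNn3c(C)nc4ccccc4c3=O)s2)cc1` share one core and differ in a single place. In a functional assay on the whole organism (strain albino) with Rattus norvegicus as the target, in the maximal electroshock model, with a stated time of 1 h, at a dose of 30 mg/kg by the intraperitoneal route (a lower number here means less inhibition, a higher number more inhibition at the dose given (going by the name of the read-out)), compound 1 gives 50% and compound 2 gives 50%; the change between them, (methoxy in place of dimethylamino on an aromatic carbon), produced a step of no change at the digits printed from compound 1 to compound 2 (within the scatter). Compound 3 `Cc1nc2ccccc2c(=O)n1NCc1nnc(N2C(=O)CSC2c2ccc(N(C)C)cc2)s1` is built on another core, and the difference between the two cores is not broken down here. In this assay compound 3 gives 60%, a number that lies within the scatter of both compound 1 and compound 2, so no order among the three can be read from it. Compound 4 `COc1ccc(C2SCC(=O)N2c2nnc(CNn3c(C)nc4ccccc4c3=O)s2)cc1` has not yet been measured in this assay. It differs from compound 3 by methoxy in place of dimethylamino on an aromatic carbon, the same change, at the same place, that turned compound 1 into compound 2. Because the earlier step was no change at the digits printed from compound 1 to compound 2 (within the scatter), the step from compound 3 to compound 4 is expected to be no change at the digits printed from compound 3 to compound 4 (within the scatter). Compound 4 is therefore estimated to give 60%, expected to fall between 40% and 70%.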

Compound 4, a percentage reported as inhibition, in the whole organism at one dose (the size of the read-out at that dose, not a potency): 60%
Compound 4: middle estimate and measured number agree at the digits printed; low and high end bracket the measured number.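

In this assay, exchanging the 4-(dimethylamino)phenyl for the 4-methoxyphenyl gives a step of no change at the digits printed from compound 3 to compound 4 (within the scatter), and this step agrees with the one seen earlier on the other core: the same change on two cores in this assay, no change at the digits printed (within the scatter) from compound 1 to compound 2 and no change at the digits printed (within the scatter) from compound 3 to compound 4, 0 percentage points apart, within the scatter of two such steps Within this series, then, the change behaves alike on the two cores shown, and the result on one core was a fair guide to the result on the other. This does not show that the two groups are equivalent in general or that the same would hold on a third core, since it rests on just two pairs of compounds, and a read-out at a single dose is a size of effect, not a potency, so a small difference could stay hidden in the scatter.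

What the compounds shown leave open is how a group of a different kind at the same place, such as a carboxylic acid, a primary amine or a longer alkoxy chain, would read in this assay. They also leave open whether such a group would behave alike on both cores, as the methoxy group does.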